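From pyrrolidin-1-yl to morpholin-4-yl in compound 4

A few compounds are considered here, and "the series" means these few. Any claim that something is new, unique, unknown or untested is made for them only; others in the source may bear on it.

Of the compounds shown here, three sharing one core have been measured in a functional assay on HCT-116 cells (Homo sapiens) for cytotoxicity, read by MTT assay, with a stated time of 72 h; on this read-out higher numbers stand for weaker inhibition and lower numbers for stronger inhibition. Compound 1 (`COc1ncc(-c2ccc3nc(NC(=O)NCC(=O)N4CCCCC4)nn3c2)cc1NS(=O)(=O)c1ccc(F)cc1`) gives 130 nM, compound 2 (`COc1ncc(-c2ccc3nc(NC(=O)NC4CC4)nn3c2)cc1NS(=O)(=O)c1ccc(F)cc1`) gives 90 nM and compound 3 (`COc1ncc(-c2ccc3nc(NC(=O)NCC(=O)N4CCCC4)nn3c2)cc1NS(=O)(=O)c1ccc(F)cc1`) gives 140 nM. Compound 3 thus stands level with the other two, since its value lies within the scatter of both.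

Compound 4 (`COc1ncc(-c2ccc3nc(NC(=O)NCC(=O)N4CCOCC4)nn3c2)cc1NS(=O)(=O)c1ccc(F)cc1`) differs from compound 3 in one place, with morpholin-4-yl in place of pyrrolidin-1-yl on a carbonyl carbon. The closest measured precedent is a change at that same carbonyl carbon, pyrrolidin-1-yl in place of piperidin-1-yl, which gave a 1.1-fold higher number from compound 1 to compound 3 (0.03 log units; within the scatter). Exchanging the whole group on the amide-type nitrogen also moved little, with a 1.4-fold lower number from compound 1 to compound 2 (0.16 log units; within the scatter) and a 1.6-fold higher number from compound 2 to compound 3 (0.19 log units; within the scatter), and all three steps stay within the scatter. For the measured compounds named here, no measured compound carries morpholin-4-yl, so the data do not show that group directly. On these three steps, no change beyond the scatter is expected in this assay. The expected step is a 1.1-fold higher number from compound 3 to compound 4 (0.03 log units; within the scatter), which would stay within the scatter. For compound 4 the estimated value is 150 nM, with an expected range from 70 nM to 320 nM.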

Compound 4, half-maximal inhibitory concentration: 490 nM
The estimate for compound 4 lay 3.3-fold (0.51 log units) below the measured number; the measured number lies above the stated range.
By their numbers in this assay, from the lowest: compounds 2, 1 and 3 (each within the scatter of the next); then compound 4.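

In this assay, for the compounds shown here, the group on the carbonyl carbon proves less tolerant of change than the earlier compounds suggested: morpholin-4-yl gives a 3.5-fold higher number from compound 3 to compound 4 (0.54 log units; beyond the scatter) and a 3.8-fold higher number from compound 1 to compound 4 (0.58 log units; beyond the scatter), both beyond the scatter, whereas the exchange of the two rings without oxygen, a 1.1-fold higher number from compound 1 to compound 3 (0.03 log units; within the scatter), stayed within it. Replacing cyclopropyl on the amide-type nitrogen with ((morpholin-4-yl)carbonyl)methyl gives a 5.4-fold higher number from compound 2 to compound 4 (0.74 log units; beyond the scatter), also beyond the scatter, so compound 4 is the weakest of the four, while the other three remain within the scatter of one another. Ring size alone does not separate these compounds, since compound 1 also carries a six-membered ring and stays within the scatter of compound 3, and only compound 4 has the ring oxygen. Nothing shown here gives a cause for this loss of activity.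

The compounds shown leave open whether the ring oxygen itself matters, which a thiomorpholin-4-yl or 4-methylpiperazin-1-yl group on the same carbonyl carbon could test. They also leave open whether an open-chain dimethylamino group there would fall with compound 3 or with compound 4.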